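The source may report more compounds than this note shows. Statements on the series, on what has been measured and on what is new or still open speak of the compounds shown alone.

Measured so far:
Compound 1, `Cc1ccc(NC(=O)Nc2nc(-c3cc4ccccc4o3)cs2)cc1`, in a physicochemical assay, with a stated time of 6 min (a higher number here means a weaker inhibitor, a lower number a stronger inhibitor), gives 500 nM.
Compound 2, `O=C(Nc1ccc(Br)cc1)Nc1nc(-c2cc3ccccc3o2)cs1`, reaches only the limit of this assay, > 200000 nM.
Compound 3, `O=C(Nc1cccc(Cl)c1)Nc1nc(-c2cc3ccccc3o2)cs1`, in this assay gives 14100 nM.

Among the two actual numbers, compound 3 stands highest; its nearest neighbour is compound 1, reached by a 28-fold higher number from compound 1 to compound 3 (1.45 log units; beyond the scatter). The value of compound 2 is a limit, and the step of an at least 14-fold lower number from compound 2 to compound 3 (1.15 log units; beyond the scatter) is therefore only a bound.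

Compound 4, `COc1ccc(NC(=O)Nc2nc(-c3cc4ccccc4o3)cs2)cc1`, has not yet been measured. It differs from compound 3 in one place: 4-methoxyphenyl in place of 3-chlorophenyl on an amide-type nitrogen.

Going by the values given here, three measured steps bear on this change, all large and all beyond the scatter: a 28-fold higher number from compound 1 to compound 3 (1.45 log units; beyond the scatter), an at least 400-fold higher number from compound 1 to compound 2 (2.60 log units; beyond the scatter) and an at least 14-fold lower number from compound 2 to compound 3 (1.15 log units; beyond the scatter). They show that the group on this nitrogen moves the read-out over a very wide span, with the 4-methylphenyl of compound 1 giving by far the lowest number and the 4-bromophenyl of compound 2 giving only a limit (the limit of > 200000 nM in this assay, at which 1 of the 3 values shown sits). A 4-methoxyphenyl is a new group, so the direction rests on the spread seen so far. The writer expects a lower number for compound 4 than for compound 3, with a 4.7-fold lower number from compound 3 to compound 4 (0.67 log units; beyond the scatter) as the estimated step, but with wide uncertainty. The estimate for compound 4 in this assay is 3000 nM, within a range from 400 nM to 40000 nM.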

Compound 4, half-maximal inhibitory concentration: 17400 nM
Beside the measured number, compound 4's estimate is 5.8-fold (0.76 log units) below it; the measured number falls inside the stated range.
By their numbers in this assay, from the lowest: compound 1; then compounds 3 and 4 (each within the scatter of the next). At a limit, above all of these: compound 2.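

In this assay, 4-methoxyphenyl and 3-chlorophenyl on an amide-type nitrogen cannot be told apart, with a 1.2-fold higher number from compound 3 to compound 4 (0.09 log units; within the scatter), so two groups that differ in both their substituent and its place on the phenyl ring give matching read-outs here. A large change, by contrast, comes when the methyl group on the aromatic carbon is replaced by a methoxy group, with a 35-fold higher number from compound 1 to compound 4 (1.54 log units; beyond the scatter), which leaves compound 1 alone with the lowest number and shows that its 4-methylphenyl is not matched by a second group of similar size at that place. Methoxy in place of bromo gives an at least 11-fold lower number from compound 2 to compound 4 (1.06 log units; beyond the scatter), but this step is only a bound, since compound 2 stands at a limit: the limit of > 200000 nM in this assay, at which 1 of the 4 values shown sits.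

From the compounds shown here alone, what remains open is how narrow the demand at that aromatic carbon is: whether an ethyl group, a longer chain or an amine there would stay close to compound 1 or fall towards compound 4. Going by these compounds, it is also open whether the match between compound 3 and compound 4 would hold for other groups on the same nitrogen, such as a carboxylic acid on the phenyl ring.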